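The source may hold more compounds than are shown below. What is called first, only, known or untested is meant among the compounds shown, and "the series" means these compounds.

Measured in a functional assay on HCT-116 cells (Homo sapiens) for antiproliferative activity, read by MTT assay, with a stated time of 48 h; on this read-out higher numbers stand for weaker inhibition and lower numbers for stronger inhibition:
- compound 1 `CCCCCCCC(CCO)n1cnc2c(Cl)ncnc21`: 4160 nM
- compound 2 `CCCCCCC[C@@H](CCO)n1cnc2c(Cl)ncnc21`: 10700 nM

Going by the values given here, of these two numbers, compound 2 has the higher, so it is the weaker inhibitor, and compound 1 is its only neighbour. Next in the series is compound 3 `CCCCCCCC[C@@H](CCO)n1cnc2c(Cl)ncnc21`, which differs from compound 2 by methyl in place of hydrogen on a saturated chain carbon, eight bonds along the chain from an aromatic nitrogen.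

Among the compounds with values here, only one measured step is available: a 2.6-fold higher number from compound 1 to compound 2 (0.41 log units; beyond the scatter). It is modest, and it comes with the fact that one of compounds 1 and 2 is drawn with a defined configuration and the other without, at the place where they differ. Within the data shown here, no measured step changes the chain, so the data give neither size nor direction for this change. The starting point therefore remains compound 2 at 10700 nM, and no step beyond the scatter is expected in this assay.

The expected change is a 1.2-fold lower number from compound 2 to compound 3 (0.08 log units; within the scatter). For compound 3 the estimated value is 9000 nM, with an expected range of 4000 nM to 20000 nM.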

Compound 3, half-maximal inhibitory concentration: 3400 nM
The estimate for compound 3 lay 2.6-fold (0.42 log units) above the measured number; the measured number lies below the stated range.
By their numbers in this assay, from the lowest: compounds 3 and 1 (each within the scatter of the next); then compound 2.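

In this assay the chain proves responsive at this position: methyl in place of hydrogen on a saturated chain carbon, eight bonds along the chain from an aromatic nitrogen, gives a 3.1-fold lower number from compound 2 to compound 3 (0.50 log units; beyond the scatter) and so supplies the first size and direction for a chain change in the series. The direction is towards stronger inhibition, and the step is modest and rests on this single pair. Nothing in the available data bears on the origin of this step.

Open, from the compounds shown here alone, is whether a longer chain, such as one ending in butyl at this carbon, continues this direction or reverses it. Also open, going by these compounds, is how an amine or a carboxylic acid at the chain end would read in this assay.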